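Octylsulfonamide benzoic acids: swapping the biaryl for a phenethyl

The source may hold more compounds than are shown below. What is called first, only, known or untested is meant among the compounds shown, and "the series" means these compounds.

Measured so far:
compound 1, `CCCCCCCCS(=O)(=O)Nc1cc(-c2cccc(Cl)c2)ccc1C(=O)O`, 13800 nM
compound 2, `CCCCCCCCS(=O)(=O)Nc1cc(-c2cccc(F)c2)ccc1C(=O)O`, 32600 nM

In an assay on mitochondria (strain BALB/c) for inhibition of glycerol-3-phosphate acyltransferase 1, mitochondrial (Mus musculus), read by scintillation counting, with a stated time of 10 min (a higher number here means a weaker inhibitor, a lower number a stronger inhibitor), compound 2 gives the highest of the two numbers; its nearest neighbour, compound 1, is separated from it by a 2.4-fold higher number from compound 1 to compound 2 (0.37 log units; beyond the scatter). Compound 3, `CCCCCCCCS(=O)(=O)Nc1cc(CCc2ccccc2)ccc1C(=O)O`, has not yet been measured. It differs from compound 2 by phenethyl in place of 3-fluorophenyl on an aromatic carbon. Among the measured compounds shown here, only the step from compound 1 to compound 2 bears on this change, and it was modest; the phenethyl replacement is larger than a halogen swap, so the direction is uncertain. For compound 3 a step of a 1.1-fold lower number from compound 2 to compound 3 (0.04 log units; within the scatter) is expected, amounting to an estimated 30000 nM, within 8000 nM to 120000 nM.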

Compound 3, half-maximal inhibitory concentration: 37500 nM
Estimate against measurement, compound 3: 1.3-fold (0.10 log units) below; the measured number falls inside the stated range.
By their numbers in this assay, from the lowest: compound 1; then compounds 2 and 3 (each within the scatter of the next).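

In this assay, at the aromatic carbon para to a carboxy group, phenethyl and 3-fluorophenyl cannot be told apart, with a 1.2-fold higher number from compound 2 to compound 3 (0.06 log units; within the scatter) separating them. Against 3-chlorophenyl the same change gives a 2.7-fold higher number from compound 1 to compound 3 (0.43 log units; beyond the scatter) and so leaves compound 1 alone at the low end of the three. Nothing measured here explains these differences. As far as these compounds go, whether a chloro on the phenethyl ring would bring the number down as it does in compound 1 stays open. So does the effect of a benzyl group, a longer link, or an amine on that ring.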